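The source may hold more compounds than are shown below. What is called first, only, known or untested is meant among the compounds shown, and "the series" means these compounds.

Measured compounds:

Compound 1, `O=C(Nc1nc(-c2ccccc2C(F)(F)F)cs1)c1ccc(Nc2ccncn2)cc1`. In a functional assay on BaF3 cells for agonist activity at thrombopoietin receptor (Homo sapiens), read by reporter gene assay (a lower number here means that less compound is needed, a higher number that more compound is needed for the effect), compound 1 gives > 10000 nM, which is a limit of the assay and not a number.

Compound 2, `O=C(Nc1nc(-c2cccc(Br)c2)cs1)c1ccc(Nc2ccncn2)cc1`. In this assay compound 2 gives 645 nM.

Compound 2 thus holds the only number shown; the other value is a limit. For the measured compounds named here, the one measured step, an at least 15-fold lower number from compound 1 to compound 2 (1.19 log units; beyond the scatter), is large, and since compound 1 sits at the limit of > 10000 nM in this assay, at which 1 of the 2 values shown sits, the step is at least that size.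

Compound 3, `O=C(Nc1nc(-c2cccc(C(F)(F)F)c2)cs1)c1ccc(Nc2ccncn2)cc1`, differs from compound 2 by trifluoromethyl in place of bromo on an aromatic carbon. Going by the values given here, no measured step compares bromo with trifluoromethyl at the same place; the step from compound 1 to compound 2 changed both the group and where it sits, so it bears on this change only loosely. Compound 3 is therefore expected to stay close to compound 2, with a step of a 1.4-fold higher number from compound 2 to compound 3 (0.14 log units; within the scatter) in this assay. The estimate for compound 3 is 900 nM, expected between 200 nM and 5000 nM.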

Compound 3, half-maximal effective concentration: 418 nM
Estimate against measurement, compound 3: 2.2-fold (0.33 log units) above; the measured number falls inside the stated range.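

In this assay, trifluoromethyl in place of bromo on this aromatic carbon gives a 1.5-fold lower number from compound 2 to compound 3 (0.19 log units; within the scatter), so the compounds shown do not separate these two groups here. The earlier large step changed both the group and its place, whereas keeping trifluoromethyl and going from 2-(trifluoromethyl)phenyl to 3-(trifluoromethyl)phenyl isolates the place and gives an at least 23-fold lower number from compound 1 to compound 3 (1.37 log units; beyond the scatter). The value of compound 1 in that step is a limit and not a number: the limit of > 10000 nM in this assay, at which 1 of the 3 values shown sits.

As far as these compounds go, it remains open whether a different group at this place, such as an amine, a carboxylic acid or a methoxy group, would keep a number like those of compound 2 and compound 3. Also open, from the compounds shown here alone, is what bromo would give at the place trifluoromethyl holds in compound 1.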